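Moving a Methyl Group on a Weak Growth Inhibitor

The source may report more compounds than this note shows. Statements on the series, on what has been measured and on what is new or still open speak of the compounds shown alone.

Measured in a functional assay on HCT-15 cells (Homo sapiens) for inhibition, read by sulforhodamine B assay; on this read-out higher numbers stand for weaker inhibition of growth and lower numbers for stronger inhibition of growth:
Compound 1 `COc1ccccc1CN1CCC=C(CCC(=O)NO)C1=O`: > 10000 nM (a limit of the assay)
Compound 2 `Cc1ccc(CN2CCC=C(CCC(=O)NO)C2=O)cc1`: 8510 nM

Going by the values given here, only two compounds have been tested so far. The result for compound 1 is a limit and not a number, as the limit of > 10000 nM in this assay, at which 1 of the 2 values shown sits, records. Among the compounds with values here, compound 2 therefore holds the only actual number in this assay, at 8510 nM.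

The next compound, compound 3 `Cc1ccccc1CN1CCC=C(CCC(=O)NO)C1=O`, has the same atoms as compound 2, joined differently. The change is 2-methylphenyl in place of 4-methylphenyl on a saturated chain carbon bound to an amide-type nitrogen in a ring, with 2-methylphenyl in place of 4-methylphenyl on a saturated chain carbon bound to an amide-type nitrogen in a ring.

Within the data shown here, no measured pair of compounds shows what a change of this kind does in this assay. With compound 2 at 8510 nM as the sole anchor, no shift in either direction beyond the usual scatter is expected. The estimated step of a 1.1-fold higher number from compound 2 to compound 3 (0.02 log units; within the scatter) is accordingly small. A result reported only as a limit would also be no surprise. The expected value for compound 3 is 9000 nM, within an estimated range of 4000 nM to 20000 nM.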

Compound 3, concentration for 50% growth inhibition: > 10000 nM
Compound 3 ended at the assay's limit; the forecaster's own chance of this, stated with the estimate: 40%; middle value at least 1.1-fold (0.04 log units) away from the limit.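

With 2-methylphenyl in place of 4-methylphenyl on a saturated chain carbon bound to an amide-type nitrogen in a ring, this assay gives an at least 1.1-fold higher number from compound 2 to compound 3 (0.07 log units; that floor lies within the scatter). Going by these compounds alone, this is the first step that can be read at all, but it is only a floor, so it shows no difference beyond the scatter and leaves the true size of the change unknown. The result for compound 3 is a limit and not a number, which leaves compound 2 as the only compound with an actual value, and the series so far consists mostly of limits: the limit of > 10000 nM in this assay, at which 2 of the 3 values shown sit.

The step between compound 1 and compound 3, methyl in place of methoxy on an aromatic carbon, cannot be read from two limits. Also open, as far as these compounds go, is whether an amine, a carboxylic acid or a longer chain in place of the methyl group would give clearly stronger inhibition of growth than compound 2 shows at 8510 nM.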